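The source may hold more compounds than are shown below. What is called first, only, known or untested is meant among the compounds shown, and "the series" means these compounds.

Within the data shown here, two measured points define the series so far. Compound 1 `Cc1ccc(C(=O)Nc2ccc3nc(NC(=O)C4CCCCC4)sc3c2)cc1` gives 5.1 ug/mL in a functional assay on WI-38 VA13 cells (Homo sapiens) for cytotoxicity (on this read-out lower numbers stand for an effect already at smaller amounts and higher numbers for an effect only at larger amounts of compound), whereas compound 2 `CCCCCCCC(=O)Nc1nc2ccc(NC(=O)c3c(Cl)cccc3Cl)cc2s1` gives 0.18 ug/mL in this assay. Compound 2 thus holds the lowest of the two numbers shown; its gap to compound 1 lies beyond the scatter, but the two compounds differ in more than one place, so no single step can be read from them. The next compound, compound 3 `O=C(Nc1nc2ccc(NC(=O)c3c(Cl)cccc3Cl)cc2s1)OCc1ccccc1`, keeps the core of compound 2 and changes one place: benzyloxy in place of heptyl on a carbonyl carbon. Among the measured compounds shown here, no step of this kind has been measured, so the expectation rests on compound 2 alone, with its 0.18 ug/mL as the starting point. Compound 3 is expected to show a moderate rise in this assay, a step of a 3.3-fold higher number from compound 2 to compound 3 (0.52 log units; beyond the scatter) somewhat beyond the scatter, though a value within the scatter of compound 2 cannot be excluded. The estimate for compound 3 is 0.6 ug/mL, within a range from 0.15 ug/mL to 3 ug/mL.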

Compound 3, half-maximal effective concentration: 0.018 ug/mL
Compound 3: the middle estimate sits 33-fold (1.52 log units) above what was measured, and the stated range ends above it.
By their numbers in this assay, from the lowest: compound 3; then compound 2; then compound 1.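

At the carbonyl carbon whose other neighbour is the amide-type nitrogen, the series now has its first single-place step: in this assay, benzyloxy in place of heptyl gives a 10-fold lower number from compound 2 to compound 3 (1.00 log units; beyond the scatter), beyond the scatter. The position therefore accepts more than a plain alkyl chain, and here a group with an aromatic ring and an oxygen carries the lower number. Nothing at hand bears on the reason for this step.

The change brings in the ring and the oxygen together, so the compounds shown do not separate the two; a heptyloxy group, which keeps the chain and adds the oxygen, or a benzyl group, which keeps the ring without the oxygen, would address that. Also open, going by these compounds, is how this position responds to an amine or a carboxylic acid on the group.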